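Compound 4: pyridin-4-yl in place of pyridin-3-yl

A few compounds are considered here, and "the series" means these few. Any claim that something is new, unique, unknown or untested is made for them only; others in the source may bear on it.

In a functional assay on MCF7 cells (Homo sapiens) for cytotoxicity, read by MTT assay, with a stated time of 48 h (on this read-out lower numbers stand for stronger inhibition and higher numbers for weaker inhibition), compound 1 (`Cc1ncc([N+](=O)[O-])n1CCSc1nnc(-c2ccccc2O)o1`) gives 28300 nM and compound 2 (`Cc1cccc(-c2nnc(SCCn3c([N+](=O)[O-])cnc3C)o2)c1O`) gives 19900 nM on the same read-out. Compound 3 (`Cc1ncc([N+](=O)[O-])n1CCSc1nnc(-c2cccnc2)o1`) gives 28700 nM and stands level with both, since its two steps lie within the scatter. Compound 4 (`Cc1ncc([N+](=O)[O-])n1CCSc1nnc(-c2ccncc2)o1`) carries pyridin-4-yl in place of pyridin-3-yl on an aromatic carbon and is otherwise the same as compound 3.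

Among the measured compounds shown here, two measured steps bear on this place: 2-hydroxyphenyl gives way to pyridin-3-yl in the step of a 1.0-fold higher number from compound 1 to compound 3 (0.01 log units; within the scatter) and 2-hydroxy-3-methylphenyl does so in the step of a 1.4-fold higher number from compound 2 to compound 3 (0.16 log units; within the scatter) with neither leaving the scatter. The step of a 1.4-fold lower number from compound 1 to compound 2 (0.15 log units; within the scatter) with methyl in place of hydrogen also stays within it. For the measured compounds named here, no measured step exchanges one pyridinyl group for another, so the evidence is indirect. The expected change is a 1.1-fold lower number from compound 3 to compound 4 (0.04 log units; within the scatter) with no real direction and nothing beyond the scatter. Expected for compound 4 is 26000 nM within an estimated range of 13000 nM to 50000 nM on this evidence.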

Compound 4, half-maximal inhibitory concentration: 12600 nM
The estimate for compound 4 lay 2.1-fold (0.31 log units) above the measured number; the measured number lies below the stated range.
By their numbers in this assay, from the lowest: compounds 4, 2, 1 and 3 (each within the scatter of the next, the first and the last beyond it).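

In this assay, among the compounds shown here, pyridin-4-yl in place of pyridin-3-yl gives the first step at this place to leave the scatter (a 2.3-fold lower number from compound 3 to compound 4 (0.36 log units; beyond the scatter)), so with the same atoms joined differently, the place on the shared core still separates the two pyridinyl groups. Against 2-hydroxyphenyl, pyridin-4-yl also leaves the scatter (a 2.2-fold lower number from compound 1 to compound 4 (0.35 log units; beyond the scatter)), but against 2-hydroxy-3-methylphenyl it stays within it (a 1.6-fold lower number from compound 2 to compound 4 (0.20 log units; within the scatter)), so compound 4 is not separated from compound 2 and the hydroxyphenyl groups do not read as one set. Nothing available accounts for the difference between the two pyridinyl groups.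

As far as these compounds go, how pyridin-2-yl or a saturated amine such as piperidin-4-yl would read at this place stays open. So does whether an amino or carboxylic acid group on the pyridin-4-yl ring would keep the lower number of compound 4.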